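The source may hold more compounds than are shown below. What is called first, only, known or untested is meant among the compounds shown, and "the series" means these compounds.

Compound 1 `O=C1/C(=C/c2ccncc2)CNC/C1=C\c1ccccc1F` is the starting point of this small set. In an ADME assay on L02 cells (Homo sapiens) for cytotoxicity, read by MTT assay, with a stated time of 24 h (a higher number here means a weaker inhibitor, a lower number a stronger inhibitor), compound 1 gives 14700 nM. Compound 2 `O=C1/C(=C/c2ccncc2)CN(S(=O)(=O)c2ccccc2)C/C1=C\c1ccccc1F` carries phenylsulfonyl in place of hydrogen on an amine nitrogen in a ring, and in this assay compound 2 gives 15900 nM, so that a 1.1-fold higher number from compound 1 to compound 2 (0.03 log units; within the scatter). Compound 3 `O=C1/C(=C/c2ccncc2)CNC/C1=C\c1ccccc1C(F)(F)F` has a core that differs from the core of compound 1 by trifluoromethyl in place of fluoro on an aromatic carbon; in this assay compound 3 gives 13400 nM, and a 1.1-fold lower number from compound 1 to compound 3 (0.04 log units; within the scatter). Compound 4 `O=C1/C(=C/c2ccncc2)CN(S(=O)(=O)c2ccccc2)C/C1=C\c1ccccc1C(F)(F)F` has not yet been measured in this assay. It differs from compound 3 by phenylsulfonyl in place of hydrogen on an amine nitrogen in a ring, the same change that turned compound 1 into compound 2, at a place described in the same words, so it is the same change made on a core that by itself gave a number within the scatter of the first. Since a 1.1-fold higher number from compound 1 to compound 2 (0.03 log units; within the scatter), a step of similar size is expected here, estimated as a 1.1-fold higher number from compound 3 to compound 4 (0.03 log units; within the scatter). On that basis compound 4 is expected to give about 14500 nM in this assay, with a range estimated from 7500 nM to 28000 nM.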

Compound 4, half-maximal inhibitory concentration: 12300 nM
Compound 4: the middle estimate sits 1.2-fold (0.07 log units) above what was measured; low and high end bracket the measured number.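

In this assay, going by these compounds alone, putting phenylsulfonyl in place of hydrogen on the amine nitrogen in a ring gives a 1.1-fold lower number from compound 3 to compound 4 (0.04 log units; within the scatter), and this agrees with the same change on the other core: the same change on two cores in this assay, a 1.1-fold higher number (0.03 log units; within the scatter) from compound 1 to compound 2 and a 1.1-fold lower number (0.04 log units; within the scatter) from compound 3 to compound 4, 1.2-fold (0.07 log units) apart, within the scatter of two such steps Putting trifluoromethyl in place of fluoro on an aromatic carbon gives a 1.3-fold lower number from compound 2 to compound 4 (0.11 log units; within the scatter), which also agrees with its earlier counterpart: the same change on two cores in this assay, a 1.1-fold lower number (0.04 log units; within the scatter) from compound 1 to compound 3 and a 1.3-fold lower number (0.11 log units; within the scatter) from compound 2 to compound 4, 1.2-fold (0.07 log units) apart, within the scatter of two such steps Each change therefore behaves alike on the two cores, but every one of these steps lies within the scatter, so this shows only that neither change has a clear effect here, not that a change with a clear effect would carry from one core to another.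

The compounds shown leave open whether another group on the ring nitrogen, such as an acetyl or a methyl group, would give a step beyond the scatter. The same question stands for a nitrile or a methoxy group in place of fluoro on the aromatic carbon.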